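The source may hold more compounds than are shown below. What is called first, only, known or untested is meant among the compounds shown, and "the series" means these compounds.

Measured so far in a functional assay on HEL cells (Homo sapiens) for cytotoxicity, read by microscopy; a lower number here means that less compound is tolerated, a higher number that more compound is tolerated:
Compound 1 `Cc1cn([C@@H]2O[C@H](CO[Si](C)(C)C(C)(C)C)[C@@]3(OS(=O)(=O)C=C3NCCC(N)=O)[C@H]2O[Si](C)(C)C(C)(C)C)c(=O)n(C)c1=O` gives >= 80000 nM, which is a limit of the assay.
Compound 2 `Cc1cn([C@@H]2O[C@H](CO[Si](C)(C)C(C)(C)C)[C@@]3(OS(=O)(=O)C=C3NCCC(=O)O)[C@H]2O[Si](C)(C)C(C)(C)C)c(=O)n(C)c1=O` gives 80000 nM.
Compound 3 `COC(=O)NC1=CS(=O)(=O)O[C@@]12[C@@H](CO[Si](C)(C)C(C)(C)C)O[C@@H](n1cc(C)c(=O)n(C)c1=O)[C@@H]2O[Si](C)(C)C(C)(C)C` gives >= 50000 nM, which is also a limit.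

Compound 1 thus stands at a limit rather than at a number, and compound 3 is the other compound whose value is a limit. Compound 4 `Cc1cn([C@@H]2O[C@H](CO[Si](C)(C)C(C)(C)C)[C@@]3(OS(=O)(=O)C=C3NCC(=O)C(=O)O)[C@H]2O[Si](C)(C)C(C)(C)C)c(=O)n(C)c1=O` differs from compound 1 by carboxycarbonyl in place of carbamoylmethyl on a saturated chain carbon bound to an amine nitrogen. The measured steps starting from compound 1 are a number no higher from compound 1 to compound 2 (the limit leaves the size open) and a step that the two limits leave unreadable from compound 1 to compound 3; the remaining one is a step that the limit leaves unreadable from compound 2 to compound 3. None of these can be read in size, since the limit of >= 80000 nM in this assay, at which 1 of the 3 values shown sits, and the limit of >= 50000 nM in this assay, at which 1 of the 3 values shown sits, cap two of the three values shown. No readable step therefore bears on the change to compound 4, and no shift beyond the scatter is expected in either direction. Compound 4 is expected to give 80000 nM, between 40000 nM and 160000 nM, a step of a number no higher from compound 1 to compound 4 (the limit leaves the size open) from compound 1.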

Compound 4, minimum cytotoxic concentration: 400000 nM
The estimate for compound 4 lay 5.0-fold (0.70 log units) below the measured number; measured number outside the range, above it.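

In this assay, the change to carboxycarbonyl on the chain gives a 5.0-fold higher number from compound 2 to compound 4 (0.70 log units; beyond the scatter). Within the data shown here, this is the first step in the set that can be read, and it shows that the number responds to a change at this place on the chain. The steps to compound 4 from compound 1 and from compound 3 cannot be read, since both of those compounds stand at limits.

On these data alone, whether a longer chain or an amine at the end of the chain would move the number further remains open. A single readable step also cannot show whether the shift would hold on another core.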